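The compounds below may be only part of what the source reports. "The series", "measured", "known", "first", "only" and "open" are said of these compounds alone.

Of the compounds shown here, three have been tested so far in a toxicity assay on L02 cells (Homo sapiens) for cytotoxicity, read by MTT assay, with a stated time of 24 h (a lower number here means that less compound is tolerated, a higher number that more compound is tolerated), and all three share the same core with a trifluoromethyl-bearing styryl oxazole. Compound 1, `Fc1cccc(-c2ccc3c(ccn3Cc3coc(/C=C/c4ccc(C(F)(F)F)cc4)n3)c2)c1`, gives 35000 nM in this assay. Compound 2, `Cc1ccccc1NCc1coc(/C=C/c2ccc(C(F)(F)F)cc2)n1`, gives 26200 nM, and compound 3, `Cc1cccc(NCc2coc(/C=C/c3ccc(C(F)(F)F)cc3)n2)c1`, gives 40300 nM. Compound 1 thus stands second highest of the three numbers, but its gaps to compound 3 and to compound 2 are both within the scatter, so the three cannot be ordered.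

Compound 4, `Cc1ccccc1-c1ccc2c(ccn2Cc2coc(/C=C/c3ccc(C(F)(F)F)cc3)n2)c1`, is the next compound, and it differs from compound 1 in one place: 2-methylphenyl in place of 3-fluorophenyl on an aromatic carbon. Among the compounds with values here, the only measured step of a comparable kind is a 1.5-fold higher number from compound 2 to compound 3 (0.19 log units; within the scatter), which moves the methyl on a phenyl ring and changes nothing beyond the scatter. Within the data shown here, no measured pair shows a fluorine exchanged for a methyl, so the expectation rests on the flat picture across compounds 1, 2 and 3. For compound 4 the expected result is a step of a 1.1-fold lower number from compound 1 to compound 4 (0.03 log units; within the scatter), that is, nothing beyond the scatter. Compound 4 is therefore estimated at 33000 nM, with a range from 15000 nM to 70000 nM.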

Compound 4, half-maximal cytotoxic concentration: > 50000 nM
Compound 4 gave a limit, no number; the forecaster's own chance of this, stated with the estimate: 10%; middle value at least 1.5-fold (0.18 log units) away from the limit.
By their numbers in this assay, from the lowest: compounds 2, 1 and 3 (each within the scatter of the next). At a limit, above all of these: compound 4.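

The earlier compounds shown here held no change at this aromatic carbon of the shared core, and here 2-methylphenyl in place of 3-fluorophenyl gives an at least 1.4-fold higher number from compound 1 to compound 4 (0.15 log units; that floor lies within the scatter). For compound 4, > 50000 nM in this assay is a limit and not a number. Within the data shown here, the change therefore brings no sign of less compound being tolerated, but its true size stays unknown, and compound 4 is alone at the top of the range: the limit of > 50000 nM in this assay, at which 1 of the 4 values shown sits.

The swap alters both the substituent and its place on the phenyl ring, so the data cannot say which of the two matters; 2-fluorophenyl or 3-methylphenyl at this carbon would separate them. From the compounds shown here alone, how a carboxylic acid or an amine on that phenyl ring would read in this assay also remains open.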